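Adding methoxy to the phenyl sulfone, compound 3 to 4

The compounds below may be only part of what the source reports. "The series", "measured", "known", "first", "only" and "open" are said of these compounds alone.

Measured in a functional assay on KB cells (Homo sapiens) for cytotoxicity, read by MTT assay, with a stated time of 72 h; on this read-out higher numbers stand for weaker inhibition and lower numbers for stronger inhibition:
- compound 1 `COc1ccc(S(=O)(=O)c2nc3ccccc3nc2N2CCCC2)cc1`: > 50000 nM
- compound 2 `COc1ccc(S(=O)(=O)c2nc3ccccc3nc2N2CCCC(O)C2)cc1`: 2120 nM
- compound 3 `O=S(=O)(c1ccccc1)c1nc2ccccc2nc1N1CCC(O)CC1`: 5360 nM

The entry for compound 1 is a limit of the assay and not a number. Of the two actual numbers, the higher belongs to compound 3, at 5360 nM. Compound 2 gives the lower one, 2120 nM.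

The open question is compound 4 `COc1ccc(S(=O)(=O)c2nc3ccccc3nc2N2CCC(O)CC2)cc1`. The change is methoxy in place of hydrogen on an aromatic carbon, phenyl to 4-methoxyphenyl.

Among the compounds with values here, no measured step makes this change. Within the data shown here, the one measured step, an at least 23-fold lower number from compound 1 to compound 2 (1.37 log units; beyond the scatter), is large, but it replaces pyrrolidin-1-yl with 3-hydroxypiperidin-1-yl and so sets no size here. The nearest guide is compound 2, which also holds 4-methoxyphenyl and gives 2120 nM.

A small move to a lower number is therefore expected, probably not beyond the scatter: the expected step is a 1.5-fold lower number from compound 3 to compound 4 (0.19 log units; within the scatter). For compound 4 the estimated value in this assay is 3500 nM, with an expected range of 1200 nM to 10000 nM.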

Compound 4, half-maximal inhibitory concentration: 8060 nM
Compound 4: middle estimate off by 2.3-fold (0.36 log units), on the low side; the measured number falls inside the stated range.
By their numbers in this assay, from the lowest: compound 2; then compounds 3 and 4 (each within the scatter of the next). At a limit, above all of these: compound 1.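

In this assay, within the data shown here, the step of a 1.5-fold higher number from compound 3 to compound 4 (0.18 log units; within the scatter) gives the first direct reading of methoxy in place of hydrogen on an aromatic carbon, and with 4-hydroxypiperidin-1-yl held fixed, phenyl to 4-methoxyphenyl does not move the number beyond the scatter. With 4-methoxyphenyl held fixed, the step of a 3.8-fold higher number from compound 2 to compound 4 (0.58 log units; beyond the scatter) shows that 4-hydroxypiperidin-1-yl and 3-hydroxypiperidin-1-yl are distinguishable in this series, whereas the methoxy change in this pair is not. The step of an at least 6.2-fold lower number from compound 1 to compound 4 (0.79 log units; beyond the scatter) starts from compound 1, whose entry is a limit of the assay: the limit of > 50000 nM in this assay, at which 1 of the 4 values shown sits.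

Whether methoxy gives the same small step alongside 3-hydroxypiperidin-1-yl stays open, as the compounds shown offer only one matched pair for this change. Also open, as far as these compounds go, is how a different group at this place on the ring, such as chlorine, an amine or a carboxylic acid, would read in this assay.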